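The source may hold more compounds than are shown below. What is called first, only, known or untested is meant among the compounds shown, and "the series" means these compounds.

Measured so far:
compound 1 `Nc1ccc(/C=C2\SC(=O)N(Cc3ccc(C(F)(F)F)cc3)C2=O)cc1` — 32000 nM
compound 2 `C=C(Br)C(=O)Nc1ccc(/C=C2\SC(=O)N(Cc3ccc(C(F)(F)F)cc3)C2=O)cc1` — 8000 nM
compound 3 `C=C(Br)C(=O)Nc1cccc(/C=C2\SC(=O)N(Cc3ccc(C)cc3)C2=O)c1` — 1200 nM

All three were run in a functional assay on CCRF-CEM cells (Homo sapiens) for cytotoxicity, read by cell counting, with a stated time of 3 days; a lower number here means a stronger inhibitor, a higher number a weaker inhibitor. Within this set compound 3 gives the lowest number, 1200 nM; compound 2 sits next with 8000 nM, and compound 1 is the furthest off with 32000 nM, both gaps being beyond the scatter. Compound 2 and compound 3 share the (1-bromoethenyl)carbonyl on the ring nitrogen, but the difference between their two cores is not broken down here.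

One step in the set is counted. Going from compound 2 to compound 1, the change is hydrogen in place of (1-bromoethenyl)carbonyl on a nitrogen on an aromatic ring, and it made the number a 4.0-fold higher number from compound 2 to compound 1 (0.60 log units; beyond the scatter).

Compound 4 `Cc1ccc(CN2C(=O)S/C(=C\c3cccc(N)c3)C2=O)cc1` has not yet been measured in this assay. It comes from compound 3 by hydrogen in place of (1-bromoethenyl)carbonyl on a nitrogen on an aromatic ring. The place is the same in words as for the earlier step, so this is the same change, set on the core of compound 3 instead of that of compound 2.

Within the data shown here, on that basis a step in the same direction and of about the same size is expected, a 4.0-fold higher number from compound 3 to compound 4 (0.60 log units; beyond the scatter), resting on the one earlier step, a 4.0-fold higher number from compound 2 to compound 1 (0.60 log units; beyond the scatter), which is the only occurrence in hand. For compound 4 the number in this assay is therefore estimated at 4800 nM, with a plausible range from 2000 nM to 15000 nM; the width allows for the change being carried over from one core to another on a single precedent.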

Compound 4, half-maximal inhibitory concentration: > 250000 nM
Compound 4: only a limit was reported (the forecaster's own chance of this, stated with the estimate: 5%); middle value at least 52-fold (1.71 log units) away from the limit.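

In this assay, hydrogen in place of (1-bromoethenyl)carbonyl on the ring nitrogen gives an at least 200-fold higher number from compound 3 to compound 4 (2.31 log units; beyond the scatter), so the change does not carry over from one core to the other at a single size: the same change on two cores in this assay, a 4.0-fold higher number (0.60 log units; beyond the scatter) from compound 2 to compound 1 and an at least 200-fold higher number (2.31 log units; beyond the scatter) from compound 3 to compound 4, at least 52-fold (1.71 log units) apart, beyond the scatter of two such steps

For compound 4, the entry > 250000 nM is a limit of the assay and not a number: the limit of > 250000 nM in this assay, at which 1 of the 4 values shown sits.

The number rises on both cores, but two pairs show only that the size of the step differs between these cores; they do not show how large the step on the core of compound 3 really is, nor which feature of the cores goes with the difference.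

The compounds shown leave open which part of the (1-bromoethenyl)carbonyl goes with the lower numbers of compound 2 and compound 3, since a plain acetyl group, an acryloyl group without the bromine or a saturated bromopropanoyl group on the same nitrogen would separate the bromine, the double bond and the carbonyl. They also leave open how the core differences divide up, which would need single-place pairs within the cores, such as methyl against trifluoromethyl with all else held fixed.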